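Adding a Fluorine to Compound 3: An Untested Step

A few compounds are considered here, and "the series" means these few. Any claim that something is new, unique, unknown or untested is made for them only; others in the source may bear on it.

The measured compounds in a functional assay on the whole organism for inhibition, with Mus musculus as the target, at a dose of 25 mg/kg by the oral route; a lower number here means less inhibition, a higher number more inhibition at the dose given (going by the name of the read-out):
compound 1 `Fc1cccc(N2CCN(CCCCOc3ccc4c(c3)CCC4)CC2)c1` gives 17%
compound 2 `Clc1ccc(N2CCN(CCCCOc3ccc4c(c3)CCC4)CC2)cc1` gives 33%
compound 3 `c1ccc(N2CCN(CCCOc3cccc4c3CCC4)CC2)cc1` gives 33%

Compound 3 stands level with compound 2 at the digits shown; together they hold the highest of the three numbers, and compound 1 sits a step lower. For the measured compounds named here, the one measured step in this set is a number 16 percentage points higher from compound 1 to compound 2 (beyond the scatter), a modest rise that lies beyond the scatter.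

Compound 4 `Fc1ccc(N2CCN(CCCOc3cccc4c3CCC4)CC2)cc1` has not been measured. It differs from compound 3 by fluoro in place of hydrogen on an aromatic carbon. Going by the values given here, no measured pair shows this exact change. The step from compound 1 to compound 2 is the closest comparison, but it swaps one halogen-bearing phenyl for another rather than adding a fluoro to a bare phenyl, so it bears on compound 4 only loosely. Among the compounds with values here, with one modest step as the sole guide and no direct precedent, a change of no more than the scatter is expected in this assay, in either direction.

Compound 4 is therefore estimated to sit close to compound 3, at 33%, within a range of 15% to 50%. The expected step is no change at the digits printed from compound 3 to compound 4 (within the scatter).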

Compound 4, a percentage reported as inhibition, in the whole organism at one dose (the size of the read-out at that dose, not a potency): 25%
Beside the measured number, compound 4's estimate is 8 percentage points above it, and the stated range covers the measured number.
By their numbers in this assay, from the lowest: compounds 1, 4, 2 and 3 (each within the scatter of the next, the first and the last beyond it).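

For the compounds shown here, the pair of compound 3 and compound 4 gives the first direct reading of phenyl to 4-fluorophenyl on this core in this assay: a number 8 percentage points lower from compound 3 to compound 4 (within the scatter). At this place on the six-membered aromatic ring, para to a large group, a single fluoro in place of hydrogen therefore gives two numbers that the usual scatter cannot separate. The earlier step compared only one halogen-bearing phenyl with another, whereas this pair sets a bare phenyl against a halogen-bearing one, and no measurement in hand accounts for the reading.

The compounds shown leave open how a larger group at the same place, such as chloro, methoxy or trifluoromethyl, would read on the core shared by compound 3 and compound 4. They also leave open whether phenyl to 4-fluorophenyl would read the same way on the core of compound 2, which carries a longer chain between the oxygen and the piperazine nitrogen.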